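Adding an octyl chain to a protected sugar aziridine scaffold

The source may report more compounds than this note shows. Statements on the series, on what has been measured and on what is new or still open speak of the compounds shown alone.

The study concerns two measured compounds and one that is not yet measured. Compound 1 `Cc1ccc(S(=O)(=O)N2CC2(C)CO[C@@H]2O[C@@H]3CO[C@H](c4ccccc4)O[C@@H]3[C@H](OCc3ccccc3)[C@H]2OCc2ccccc2)cc1` was tested in an ADME assay on MRC5 cells (Homo sapiens) for cytotoxicity, read by MTT assay, with a stated time of 48 h; on this read-out lower numbers stand for stronger inhibition and higher numbers for weaker inhibition. For compound 1 the result is not a number but a limit of the assay, > 1000000 nM. Its deprotected relative, compound 2 `Cc1ccc(S(=O)(=O)N2CC2(C)CO[C@@H]2O[C@@H]3CO[C@H](c4ccccc4)O[C@@H]3[C@H](O)[C@H]2O)cc1`, gives a number in this assay, 312000 nM. Compound 3 `CCCCCCCCCC1(CO[C@@H]2O[C@@H]3CO[C@H](c4ccccc4)O[C@@H]3[C@H](OCc3ccccc3)[C@H]2OCc2ccccc2)CN1S(=O)(=O)c1ccc(C)cc1` differs from compound 1 by octyl in place of hydrogen on a saturated chain carbon bound to a saturated ring carbon. Within the data shown here, no step between two measured compounds is available, so the size of the change brought by the octyl chain cannot be read from the data. Because compound 1 sits at the limit of > 1000000 nM in this assay, at which 1 of the 2 values shown sits, any change toward weaker inhibition could not be seen at all. Compound 3 is expected to stay near the limit, with the step of an at least 1.6-fold lower number from compound 1 to compound 3 (0.22 log units; that floor lies within the scatter) estimated as small, toward stronger inhibition if anything. The estimate for compound 3 is therefore 600000 nM, within a range from 100000 nM to 2000000 nM.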

Compound 3, half-maximal inhibitory concentration: 575000 nM
Compound 3: the middle estimate sits 1.0-fold (0.02 log units) above what was measured, and the stated range covers the measured number.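

With octyl in place of hydrogen on a saturated chain carbon bound to a saturated ring carbon, this assay gives an at least 1.7-fold lower number from compound 1 to compound 3 (0.24 log units; that floor lies within the scatter). Compound 3 thus gives an actual number at this position, 575000 nM, so the octyl compound can be placed on the scale of the assay. Only a floor can be stated for the step, and that floor does not establish a real change, because compound 1 has a limit rather than a number: the limit of > 1000000 nM in this assay, at which 1 of the 3 values shown sits.

On these data alone, whether a shorter chain such as butyl, a longer chain such as dodecyl, or an octyl chain ending in an amine or a carboxylic acid would give a different number at this place remains open. As far as these compounds go, it is also open what the octyl chain would do on the deprotected core of compound 2, which gives 312000 nM.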